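This account rests on a few compounds, and the source may have more. Where it says the series, first, only, none or still open, it means among the compounds named here.

Measured so far in a functional assay on the whole organism with Mus musculus as the target; on this read-out higher numbers stand for an effect only at larger amounts of compound and lower numbers for an effect already at smaller amounts:

- compound 1 (`CCCCC(C)NCC(N)=O`) gives (640 mg/kg)
- compound 2 (`NC(=O)CNCc1ccccc1`) gives (490 mg/kg)
- compound 3 (`C[C@@H](NCc1ccc(OCc2ccccc2)cc1)C(N)=O`) gives (23.8 mg/kg)

Compound 3 has the lowest of these numbers, so in this assay it shows its effect at the smallest dose. Compound 2 and compound 1 both sit far higher, and both gaps to compound 3 lie well beyond the usual scatter.

The next compound keeps most of compound 3 unchanged. In compound 4 (`CNC(=O)[C@H](CO)NCc1ccc(OCc2ccccc2)cc1`), 2-hydroxy-1-(methylcarbamoyl)ethyl stands in place of 1-carbamoylethyl on an amine nitrogen (2-hydroxy-1-(methylcarbamoyl)ethyl in place of 1-carbamoylethyl on an amine nitrogen).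

For the measured compounds named here, no pair of measured compounds differs in only one place, so nothing here shows directly what a change of this kind does. The expectation therefore starts from compound 3 (23.8 mg/kg), with the shared core assumed to carry over and the new group assumed to cost a little. The expected result is a small rise in the number, not clearly beyond the scatter, and the estimated step is (a 1.7-fold higher number from compound 3 to compound 4 (0.23 log units; within the scatter)). The range is kept wide for lack of a direct comparison. The estimate for compound 4 is (40 mg/kg), with the measurement expected between (12 mg/kg) and (130 mg/kg).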

Compound 4, dose for half-maximal effect: 15 mg/kg
The estimate for compound 4 lay 2.7-fold (0.43 log units) above the measured number, and the stated range covers the measured number.
By their numbers in this assay, from the lowest: compounds 4 and 3 (each within the scatter of the next); then compounds 2 and 1 (each within the scatter of the next).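

For the compounds shown here, compound 4 gives the first direct comparison, and for the swap of 1-carbamoylethyl for 2-hydroxy-1-(methylcarbamoyl)ethyl on an amine nitrogen, this assay shows a 1.6-fold lower number from compound 3 to compound 4 (0.20 log units; within the scatter). The two compounds therefore cannot be told apart in this test, even though the entering group is larger and has more hydrogen-bond donors and acceptors, so this position accepts at least this one larger group without a clear change in the dose needed. No measurement is available that could explain this result.

The entering group brings the hydroxy part and the methyl of the methylcarbamoyl in a single step, so the compounds shown leave open what each does alone, and whether either has its own effect that the other cancels. They also leave open how this position would respond to a group of a different kind, such as 2-hydroxy-1-carbamoylethyl, which has the hydroxy part alone, or one carrying a carboxylic acid, an amine or a longer chain.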